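The source may report more compounds than this note shows. Statements on the series, on what has been measured and on what is new or still open speak of the compounds shown alone.

Compound 1, `COc1ccc(/C=C/C2CC(=O)C=CO2)cc1OC`, and compound 2, `COc1cc(/C=C/C2CC(=O)C=CO2)cc(OC)c1OC`, share one core. In a functional assay on HT-29 cells (Homo sapiens) for inhibition, read by sulforhodamine B assay, with a stated time of 48 h (a higher number here means a weaker inhibitor of growth, a lower number a stronger inhibitor of growth), compound 1 gives 123 uM, and compound 2 gives 135 uM. The change between them is methoxy in place of hydrogen on an aromatic carbon, and the step is a 1.1-fold higher number from compound 1 to compound 2 (0.04 log units; within the scatter).

Compound 3, `COc1ccc(/C=C/c2cc(=O)cco2)cc1`, has a different core; how the two cores differ is not broken down here. In this assay compound 3 gives 379 uM, the highest of the three numbers, beyond the scatter from compound 1 and from compound 2.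

Compound 4, `COc1ccc(/C=C/c2cc(=O)cco2)cc1OC`, is not yet measured. It differs from compound 3 by methoxy in place of hydrogen on an aromatic carbon. This is the same kind of change as that from compound 1 to compound 2, not the same: there the entering methoxy was also meta to a methoxy group, here it is not. Because a 1.1-fold higher number from compound 1 to compound 2 (0.04 log units; within the scatter) lay within the scatter, the step from compound 3 to compound 4 in this assay is expected to be a 1.1-fold higher number from compound 3 to compound 4 (0.02 log units; within the scatter). Compound 4 is therefore estimated at 400 uM, between 200 uM and 800 uM.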

Compound 4, concentration for growth inhibition (reported as GI): 807 uM
Beside the measured number, compound 4's estimate is 2.0-fold (0.30 log units) below it; the measured number lies above the stated range.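

In this assay, methoxy in place of hydrogen on the aromatic carbon gives a 2.1-fold higher number from compound 3 to compound 4 (0.33 log units; beyond the scatter), a modest step, while the same kind of change on the other core gave a 1.1-fold higher number from compound 1 to compound 2 (0.04 log units; within the scatter). Set side by side, the two steps cannot be told apart, so the change shows no firm dependence on the core: the same change on two cores in this assay, a 1.1-fold higher number (0.04 log units; within the scatter) from compound 1 to compound 2 and a 2.1-fold higher number (0.33 log units; beyond the scatter) from compound 3 to compound 4, 1.9-fold (0.29 log units) apart, within the scatter of two such steps. Within the data shown here, this does not show that the step is the same on both cores, since two pairs cannot settle that and only the step on the core of compound 3 lies beyond the scatter.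

The compounds shown leave open how a hydroxyl group or an amine would read in this place in this assay. They also leave open whether a third methoxy on the core of compound 4 would continue the step seen there.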